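This account rests on a few compounds, and the source may have more. Where it says the series, first, only, none or still open, it means among the compounds named here.

Compound 2 `C#CCN1CCN(CC(=O)N2CCN(c3ccc(C(=O)c4cc5ccc(N(CC)CC)cc5o4)cc3)CC2)CC1` is where this part begins. In a functional assay on MCF7 cells (Homo sapiens) for cytotoxicity, read by MTT assay, with a stated time of 48 h (on this read-out higher numbers stand for weaker inhibition and lower numbers for stronger inhibition), compound 2 gives > 40000 nM, which is a limit of the assay rather than a number, and it sits at the limit of > 40000 nM in this assay, at which 1 of the 2 values shown sits. Compound 3 `CCN(CC)c1ccc2cc(C(=O)c3ccc(N4CCN(C(=O)CN5CCN(Cc6ccc(F)c(F)c6)CC5)CC4)cc3)oc2c1` differs from it by 3,4-difluorophenyl in place of ethynyl on a saturated chain carbon bound to an amine nitrogen in a ring. Going by the values given here, the one measured step that bears on this is an at least 1.9-fold higher number from compound 1 to compound 2 (0.29 log units; that floor lies within the scatter), and compound 1 `CCN(CC)c1ccc2cc(C(=O)c3ccc(N4CCN(C(=O)CN5CCN(S(=O)(=O)c6ccc(F)cc6)CC5)CC4)cc3)oc2c1` gives 20500 nM in this assay. Since compound 3 again carries a six-membered aromatic ring here, a number close to compound 1 is expected. Compound 3 is therefore estimated at 25000 nM, within 8000 nM to 60000 nM, which would mean the step of an at least 1.6-fold lower number from compound 2 to compound 3 (0.20 log units; that floor lies within the scatter).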

Compound 3, half-maximal inhibitory concentration: 9220 nM
Compound 3: the middle estimate sits 2.7-fold (0.43 log units) above what was measured; the measured number falls inside the stated range.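

In this assay, the group on this amine nitrogen in a ring now makes a difference beyond the scatter, which the earlier change from (4-fluorophenyl)sulfonyl to propargyl did not show. The 3,4-difluorobenzyl group gives an at least 4.3-fold lower number from compound 2 to compound 3 (0.63 log units; beyond the scatter), and it also gives a 2.2-fold lower number from compound 1 to compound 3 (0.35 log units; beyond the scatter). The first of these steps has only a floor, and compound 2 stands at a limit of the assay rather than a number: the limit of > 40000 nM in this assay, at which 1 of the 3 values shown sits.

On these data alone, whether the two fluorines contribute remains open, and a plain benzyl would address that. As far as these compounds go, how a carboxylic acid or an amine on the benzyl ring would read is also open.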